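The compounds below may be only part of what the source reports. "The series", "measured", "known", "first", "only" and "open" are said of these compounds alone.

Measured in a functional assay on PC-3 cells (Homo sapiens) for antiproliferative activity, read by CCK-8 assay, with a stated time of 6 days; a lower number here means a stronger inhibitor, a higher number a weaker inhibitor:
- compound 1 `CCN(c1ccc(C#N)c(Cl)c1)c1cc(-c2ccncc2)ccc1C`: 3580 nM
- compound 2 `CCN(c1ccc(C#N)c(Cl)c1)c1cc(-c2ccnn2C)ccc1C`: 7290 nM
- compound 3 `CCN(c1ccc(C#N)c(Cl)c1)c1cc(-c2c[nH]nc2C)ccc1C`: 9030 nM

Compound 3 stands level with its nearest neighbour, with a 1.2-fold higher number from compound 2 to compound 3 (0.09 log units; within the scatter). It is clearly separated only from the other compound, with a 2.5-fold higher number from compound 1 to compound 3 (0.40 log units; beyond the scatter).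

The next structure, compound 4 `CCN(c1ccc(C#N)c(Cl)c1)c1cc(-n2ccnc2)ccc1C`, carries 1H-imidazol-1-yl in place of 3-methyl-1H-pyrazol-4-yl on an aromatic carbon.

Going by the values given here, no measured compound carries this group, so the evidence is indirect. Exchanging this ring has so far moved the number only modestly, as in a 2.0-fold higher number from compound 1 to compound 2 (0.31 log units; beyond the scatter). No change beyond the scatter is therefore expected, and the direction is uncertain. The expected result is a 1.5-fold lower number from compound 3 to compound 4 (0.18 log units; within the scatter). For compound 4 the estimate is 6000 nM, with an expected range of 2500 nM to 14000 nM.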

Compound 4, half-maximal inhibitory concentration: > 30000 nM
Compound 4 ended at the assay's limit; the forecaster's own chance of this, stated with the estimate: 5%; middle value at least 5.0-fold (0.69 log units) from the limit.
By their numbers in this assay, from the lowest: compound 1; then compounds 2 and 3 (each within the scatter of the next). At a limit, above all of these: compound 4.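

In this assay compound 4 sits at a limit and gives no exact number: the limit of > 30000 nM in this assay, at which 1 of the 4 values shown sits. Even so, this position proves less forgiving than the earlier ring exchanges suggested, since placing 1H-imidazol-1-yl here gives an at least 3.3-fold higher number from compound 3 to compound 4 (0.52 log units; beyond the scatter) and an at least 4.1-fold higher number from compound 2 to compound 4 (0.61 log units; beyond the scatter) and also an at least 8.3-fold higher number from compound 1 to compound 4 (0.92 log units; beyond the scatter) as steps beyond the scatter. The ring attached here therefore matters, and a five-membered aromatic ring with two nitrogens does not guarantee that compound 2 or compound 3 will be matched.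

Still open, from the compounds shown here alone, is whether the loss follows from attachment through ring nitrogen or from the absent methyl group. An imidazole joined through carbon, or a pyridine carrying an amine, would help separate these possibilities.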